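Replacing methyl with trifluoromethoxy in compound 3

The source may hold more compounds than are shown below. What is called first, only, known or untested is meant among the compounds shown, and "the series" means these compounds.

In a functional assay on LoVo cells (Homo sapiens) for inhibition, read by MTT assay, with a stated time of 72 h (a higher number here means a weaker inhibitor, a lower number a stronger inhibitor), compound 1 (`C=C(Br)C(=O)Nc1cccc(/C=C/C(=O)Nc2ccc(F)c(F)c2)c1`) gives 540 nM. Compound 2 (`C=C(Br)C(=O)Nc1cccc(/C=C/C(=O)Nc2ccc(Cl)cc2)c1`) gives 5900 nM. Compound 3 (`C=C(Br)C(=O)Nc1cccc(/C=C/C(=O)Nc2ccc(C)cc2)c1`) falls between them at 1500 nM, the second highest of the three numbers.

Compound 4 (`C=C(Br)C(=O)Nc1cccc(/C=C/C(=O)Nc2ccc(OC(F)(F)F)cc2)c1`) has trifluoromethoxy in place of methyl on an aromatic carbon, para to a large group: trifluoromethoxy in place of methyl on an aromatic carbon.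

The most relevant measured change is at that same carbon. It is a 3.9-fold lower number from compound 2 to compound 3 (0.59 log units; beyond the scatter), a modest step beyond the scatter, and it shows methyl giving the lower number of the two. The other two steps, a 2.8-fold higher number from compound 1 to compound 3 (0.44 log units; beyond the scatter) and an 11-fold higher number from compound 1 to compound 2 (1.04 log units; beyond the scatter), are modest and large, so changes to this ring can move the number considerably. Only chloro and methyl have been compared at this carbon, so the evidence for trifluoromethoxy is thin. A modest rise is expected, with wide uncertainty. The estimated change is a 2.1-fold higher number from compound 3 to compound 4 (0.33 log units; beyond the scatter). For compound 4 the expected value is 3200 nM, with an estimated range of 1000 nM to 9000 nM.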

Compound 4, half-maximal inhibitory concentration: 30300 nM
Beside the measured number, compound 4's estimate is 9.5-fold (0.98 log units) below it; the measured number lies above the stated range.
By their numbers in this assay, from the lowest: compound 1; then compound 3; then compound 2; then compound 4.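

In this assay, trifluoromethoxy at this aromatic carbon gives a 20-fold higher number from compound 3 to compound 4 (1.31 log units; beyond the scatter), and against chloro it gives a 5.1-fold higher number from compound 2 to compound 4 (0.71 log units; beyond the scatter). The earlier compounds had shown only that chloro gave a higher number than methyl; compound 4 now extends the order at this carbon to methyl, chloro, then trifluoromethoxy, and shows that a single replacement here can produce a large step. Nothing measured on these compounds explains that order.

The compounds shown leave open how an amine, a methoxy group or a plain hydrogen at this carbon would read, and so whether methyl gives the lowest number generally or only among these three groups. They also leave open whether trifluoromethoxy would raise the number as sharply alongside a second ring substituent, such as the extra fluorine of the 3,4-difluorophenyl group in compound 1.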